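The source may report more compounds than this note shows. Statements on the series, on what has been measured and on what is new or still open speak of the compounds shown alone.

Series notes. Compound 1 `COc1nc(C2CCCCC2)ccc1[C@@H](c1ccccc1)[C@@](O)(CCN(C)C)c1cccc2ccccc12` carries cyclohexyl on the shared core; in a toxicity assay on HeLa cells (Homo sapiens) for cytotoxicity (a lower number here means that less compound is tolerated, a higher number that more compound is tolerated), compound 1 gives 57.7 ug/mL. Compound 2 `COc1nc(-c2ccc(Br)cc2)ccc1[C@@H](c1ccccc1)[C@@](O)(CCN(C)C)c1cccc2ccccc12` carries 4-bromophenyl in its place. In this assay compound 2 gives > 64 ug/mL, a limit of the assay and not a number. Compound 3 `COc1nc(-c2ccc(F)cc2)ccc1[C@@H](c1ccccc1)[C@@](O)(CCN(C)C)c1cccc2ccccc12` carries 4-fluorophenyl. In this assay compound 3 gives > 64 ug/mL, again a limit and not a number. The measured steps read an at least 1.1-fold higher number from compound 1 to compound 2 (0.04 log units; that floor lies within the scatter) and an at least 1.1-fold higher number from compound 1 to compound 3 (0.04 log units; that floor lies within the scatter), while a step that the two limits leave unreadable from compound 2 to compound 3. Compound 3 therefore stands at the limit of > 64 ug/mL in this assay, at which 2 of the 3 values shown sit, and its standing against compound 2 cannot be read from the numbers shown.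

Compound 4 `COc1nc(-c2ccc(OC(F)(F)F)cc2)ccc1[C@@H](c1ccccc1)[C@@](O)(CCN(C)C)c1cccc2ccccc12` is not yet measured. It differs from compound 3 in one place: trifluoromethoxy in place of fluoro on an aromatic carbon. Among the measured compounds shown here, the only measured step touching the same position, fluoro to bromo, is unreadable, so no direction is set by the data. For compound 4 in this assay the expected value is 70 ug/mL, within 40 ug/mL to 128 ug/mL. That estimate means a step that the limit leaves unreadable from compound 3 to compound 4, expected to lie within the scatter.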

Compound 4, half-maximal cytotoxic concentration: > 64 ug/mL
Compound 4 ended at the assay's limit (the forecaster's own chance of this, stated with the estimate: 70%); the middle value is on the limit's open side.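

Trifluoromethoxy, at 5 heavy atoms where fluoro has 1, brings no finite value into view in this assay, so this place on the aromatic ring has now held three different groups without a number to separate them: the limit of > 64 ug/mL in this assay, at which 3 of the 4 values shown sit. Among the compounds shown here, the only readable step is an at least 1.1-fold higher number from compound 1 to compound 4 (0.04 log units; that floor lies within the scatter), which gives a floor and no measured size. The steps among compound 2, compound 3 and compound 4 cannot be read, as all three values are limits.

Going by these compounds, whether any of these three aryl compounds truly differs from compound 1 beyond the scatter, and how they rank among themselves, remains open. Also open, on these data alone, is whether an amine or a carboxylic acid on this aromatic ring would give a value below the limit in this assay.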